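This account rests on a few compounds, and the source may have more. Where it says the series, first, only, none or still open, it means among the compounds named here.

Measured compounds in an assay on cell membranes for displacement of a labelled ligand from corticotropin-releasing factor receptor 1 (Rattus norvegicus); on this read-out lower numbers stand for stronger inhibition and higher numbers for weaker inhibition:
- compound 1 `CCC(CC)Nc1nc(C)nc2c(-c3c(C)cc(N(C)C)nc3C)c(C)nn12`: 25.6 nM
- compound 2 `CCC(CC)Nc1nc(C)nc2c(-c3cnc(N(C)C)cc3C)c(C)nn12`: 24.8 nM
- compound 3 `CCCCN(CCC)c1nc(C)nc2c(-c3ccc(OC)nc3C)c(C)nn12`: 2.4 nM

Compound 1 gives the highest number of the three in this assay. Compound 2 sits within the scatter of it, the measured step being a 1.0-fold lower number from compound 1 to compound 2 (0.01 log units; within the scatter). Compound 3 gives a lower number, beyond the scatter, but it differs from compound 1 in more than one place and so no single step can be read from that pair.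

Compound 4 `COCCNc1nc(C)nc2c(-c3c(C)cc(N(C)C)nc3C)c(C)nn12` arises from compound 1 by 2-methoxyethyl in place of pentan-3-yl on a nitrogen on an aromatic ring. Among the compounds with values here, none of the measured steps touches the nitrogen on an aromatic ring; the one step measured concerns a methyl on an aromatic carbon and lies within the scatter. Within the data shown here, there is thus no direct precedent for the pentan-3-yl to 2-methoxyethyl exchange, and the size of the step is uncertain. On balance a weaker result is expected for compound 4, estimated at 70 nM with a range of 18 nM to 280 nM, a step of a 2.7-fold higher number from compound 1 to compound 4 (0.44 log units; beyond the scatter).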

Compound 4, half-maximal inhibitory concentration: > 10000 nM
Compound 4 ended at the assay's limit; the forecaster's own chance of this, stated with the estimate: 5%; at least 140-fold (2.15 log units) between middle value and limit.
By their numbers in this assay, from the lowest: compound 3; then compounds 2 and 1 (each within the scatter of the next). At a limit, above all of these: compound 4.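

Among the steps measured so far, this is the first to go beyond the scatter in this assay: an at least 390-fold higher number from compound 1 to compound 4 (2.59 log units; beyond the scatter). Compound 4 stands at a limit of the assay, not at a number: the limit of > 10000 nM in this assay, at which 1 of the 4 values shown sits. The group on this nitrogen thus counts for far more here than the methyl on an aromatic carbon, whose step is a 1.0-fold lower number from compound 1 to compound 2 (0.01 log units; within the scatter).

The compounds shown leave open whether the oxygen or the loss of branching in the chain accounts for the change. An unbranched butyl chain or a 3-methoxypropyl chain on this nitrogen would separate the two.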